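A Benzylamine Swap on the Shared Core

The source may report more compounds than this note shows. Statements on the series, on what has been measured and on what is new or still open speak of the compounds shown alone.

Among the measured compounds shown here, compound 1 `Nc1cc(N)c2nc(-c3ccccc3)c(NCc3ccc(Cl)c(Cl)c3)nc2c1` is one of two compounds so far tested in a functional assay on MDA-MB-231 cells (Homo sapiens) for inhibition, read by sulforhodamine B assay, with a stated time of 48 h (on this read-out higher numbers stand for weaker inhibition of growth and lower numbers for stronger inhibition of growth), where compound 1 gives 1580 nM. That is the lower of the two numbers: compound 2 `Nc1cc(N)c2nc(-c3ccccc3)c(Sc3ccc(F)cc3)nc2c1`, which carries a different group on the shared core, gives 17400 nM in this assay, and the gap between these two values lies beyond the usual scatter. For the measured compounds named here, no measured pair differs in a single place, so no single step in this assay is yet known.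

Compound 3 `COc1ccc(CNc2nc3cc(N)cc(N)c3nc2-c2ccccc2)cc1` differs from compound 1 in one place: 4-methoxyphenyl in place of 3,4-dichlorophenyl on a saturated chain carbon bound to a nitrogen on an aromatic ring. Going by the values given here, with no measured step of this kind to lean on, the size of the change can only be guessed from the two numbers in hand. The step in this assay is expected to be a 2.2-fold higher number from compound 1 to compound 3 (0.35 log units; beyond the scatter), a modest move toward weaker inhibition. Compound 3 is estimated at 3500 nM in this assay, with a range from 1200 nM to 12000 nM.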

Compound 3, concentration for 50% growth inhibition: 2880 nM
Compound 3: the middle estimate sits 1.2-fold (0.08 log units) above what was measured; the measured number falls inside the stated range.
By their numbers in this assay, from the lowest: compounds 1 and 3 (each within the scatter of the next); then compound 2.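

Among the compounds shown here, replacing 3,4-dichlorophenyl with 4-methoxyphenyl on a saturated chain carbon bound to a nitrogen on an aromatic ring gives the first single-place step in this assay, and it reads a 1.8-fold higher number from compound 1 to compound 3 (0.26 log units; within the scatter). In this assay, therefore, the two groups cannot be told apart at this position, even though the exchange replaces chlorine with oxygen and introduces a hydrogen-bond acceptor. Nothing measured on these compounds offers an explanation for this result.

The compounds shown leave open whether an unsubstituted phenyl, a pyridine ring or a phenyl bearing a carboxylic acid at this position would move the number beyond the scatter. They also leave open what a longer chain between the aromatic ring and the nitrogen would do.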